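The source may report more compounds than this note shows. Statements on the series, on what has been measured and on what is new or still open speak of the compounds shown alone.

Of the compounds shown here, two of one shared core have been tested in an ADME assay on SK-OV-3 cells (Homo sapiens) for cytotoxicity, read by sulforhodamine B assay, with a stated time of 48 h, tested at 10 uM; on this read-out lower numbers stand for less inhibition and higher numbers for more inhibition at the one concentration tested (going by the name of the read-out). Compound 1 `COc1nc2ccc(Br)cc2cc1C(c1ccccc1)n1cc(-c2ccccc2)nn1` carries a phenyl on the five-membered ring and in this assay gives 13.7%. Compound 2 `COc1nc2ccc(Br)cc2cc1C(c1ccccc1)n1cc(CCCO)nn1` carries a 3-hydroxypropyl at the same place and in this assay gives 13.8%. Within the data shown here, the only measured step, a number 0.1 percentage points higher from compound 1 to compound 2 (within the scatter), shows that exchanging phenyl for 3-hydroxypropyl left the read-out unchanged, so the two numbers cannot be told apart.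

Compound 3 `COc1nc2ccc(Br)cc2cc1C(c1ccccc1)n1cc(-c2ccc(F)cc2)nn1` is the next compound to be measured. It differs from compound 2 in one place: 4-fluorophenyl in place of 3-hydroxypropyl on an aromatic carbon. The 4-fluorophenyl that enters resembles the phenyl of compound 1 far more closely than the 3-hydroxypropyl that leaves, and the step from compound 1 to compound 2 already showed no movement beyond the scatter when a phenyl and a 3-hydroxypropyl were exchanged at this position. On that basis the step of a number 0.2 percentage points higher from compound 2 to compound 3 (within the scatter) is expected to stay within the scatter. The estimate for compound 3 in this assay is therefore 14%, with a range from 4% to 25%.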

Compound 3, a percentage reported as inhibition, at one concentration (the size of the read-out at that concentration, not a potency): 14.3%
Beside the measured number, compound 3's estimate is 0.3 percentage points below it; measured number inside the range.
By their numbers in this assay, from the lowest: compounds 1, 2 and 3 (each within the scatter of the next).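

In this assay, the exchange of the chain for a ring on this aromatic carbon gives a number 0.5 percentage points higher from compound 2 to compound 3 (within the scatter), so the 4-fluorophenyl, with its six-membered aromatic ring and 0 hydrogen-bond donors, cannot be told apart from the 3-hydroxypropyl, which has no ring and 1 hydrogen-bond donor. The fluoro in place of hydrogen, the first change made on the aryl group itself rather than an exchange of the whole group, gives a number 0.6 percentage points higher from compound 1 to compound 3 (within the scatter), so this substitution also leaves no difference that can be read. Nothing available explains why the three numbers cannot be separated.

Going by these compounds, whether an amine, a carboxylic acid or a longer chain on this aromatic carbon of the five-membered aromatic ring would give a number beyond the scatter stays open, as does the effect of a methoxy or a chloro in place of the fluoro. The compounds shown also leave open whether the same holds at any other concentration, since each was read at only one.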